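The source may hold more compounds than are shown below. What is called first, only, known or untested is meant among the compounds shown, and "the series" means these compounds.

Three compounds sharing one core have been examined in an assay on membranes from HeLa cells for displacement of a labelled ligand from adenosine receptor A3 (Homo sapiens), read by scintillation counting, with a stated time of 180 min, tested at 1 uM; a higher number here means more inhibition at the concentration tested (going by the name of the read-out), a lower number less inhibition. Compound 1 `CC(=O)C1=C(C)NC(=O)NC1c1ccsc1` gives 1% in this assay. Compound 2 `CC1=C(C(=O)C2CC2)C(c2ccsc2)NC(=O)N1`, which carries a cyclopropyl in place of methyl on a carbonyl carbon, gives 1% in this assay, and the step of no change at the digits printed from compound 1 to compound 2 (within the scatter) is nothing beyond the scatter. Compound 3 `CCNC(=O)C1=C(C)NC(=O)NC1c1ccsc1`, with ethylamino in place of methyl on a carbonyl carbon, gives 1% in this assay; both no change at the digits printed from compound 1 to compound 3 (within the scatter) and no change at the digits printed from compound 2 to compound 3 (within the scatter) are likewise nothing beyond the scatter. Compound 3 therefore stands level with compounds 1 and 2 at the digits shown, nearest to compound 1 and furthest from compound 2, though neither gap exceeds the scatter.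

Compound 4 `CCN(CC)C(=O)C1=C(C)NC(=O)NC1c1ccsc1` differs from compound 3 by ethyl in place of hydrogen on an amide-type nitrogen. For the measured compounds named here, no measured step touches this amide-type nitrogen; the three steps all change the group on the carbonyl carbon, and all three were flat. Going by the values given here, with every variation so far leaving the inhibition unmoved, no step beyond the scatter is expected in this assay for this change either, and the expected step of a number 1 percentage points higher from compound 3 to compound 4 (within the scatter) is essentially none. Compound 4 is accordingly estimated at 2% in this assay, within a range from -8% to 15%.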

Compound 4, a percentage reported as inhibition, at one concentration (the size of the read-out at that concentration, not a potency): 35%
The estimate for compound 4 lay 33 percentage points below the measured number; the measured number lies above the stated range.
By their numbers in this assay, from the lowest: compounds 1, 2 and 3 (each within the scatter of the next); then compound 4.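

In this assay, the amide-type nitrogen proves to be a place where the read-out responds: ethyl in place of hydrogen there gives a number 34 percentage points higher from compound 3 to compound 4 (beyond the scatter), where every earlier change had left the number flat. The group on the carbonyl carbon therefore does matter, though only diethylamino has shown it so far, with a number 34 percentage points higher from compound 1 to compound 4 (beyond the scatter) when it replaces methyl and a number 34 percentage points higher from compound 2 to compound 4 (beyond the scatter) when it replaces cyclopropyl, while methyl, cyclopropyl and ethylamino themselves remain within the scatter of one another. No available evidence accounts for why this one added ethyl separates compound 4 from the rest.

As far as these compounds go, it remains open whether the step is particular to ethyl or would also appear with other groups on this nitrogen, such as the methyl of a dimethylamino or the longer chains of a dipropylamino or dibutylamino group on the carbonyl carbon. From the compounds shown here alone, since the read-out is taken at a single concentration, it also remains open how potent compound 4 is, and whether the same step would hold on a core bearing something other than the shared ring substituent.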